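Moving the methyl on the amide-bound phenyl of compound 1

This account rests on a few compounds, and the source may have more. Where it says the series, first, only, none or still open, it means among the compounds named here.

Compound 1 `Cc1ccccc1NC(=O)c1cc2ccccc2oc1=O`: 2960 nM
Compound 2 `COc1ccccc1NC(=O)c1cc2ccccc2oc1=O`: 35400 nM

In an assay for inhibition of Amine oxidase [flavin-containing] B (Homo sapiens), read by fluorescence, using microsomes, with a stated time of 15 min (on this read-out lower numbers stand for stronger inhibition and higher numbers for weaker inhibition), compound 1 gives 2960 nM, the lower of the two numbers shown, and compound 2 gives 35400 nM. For the measured compounds named here, the one measured step, a 12-fold higher number from compound 1 to compound 2 (1.08 log units; beyond the scatter), swaps the group on the ring rather than moving it. Compound 3 `Cc1cccc(NC(=O)c2cc3ccccc3oc2=O)c1` keeps every atom of compound 1 and differs only by 3-methylphenyl in place of 2-methylphenyl on an amide-type nitrogen. Going by the values given here, no measured step bears directly on such a move, so only a modest shift is expected, a 1.7-fold higher number from compound 1 to compound 3 (0.23 log units; within the scatter), likely toward weaker inhibition. Compound 3 is therefore estimated at 5000 nM, within 1500 nM to 20000 nM.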

Compound 3, half-maximal inhibitory concentration: 930 nM
Estimate against measurement, compound 3: 5.4-fold (0.73 log units) above; the whole stated range lies above it.
By their numbers in this assay, from the lowest: compound 3; then compound 1; then compound 2.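

In this assay, moving the methyl alone, with no atom gained or lost, gives a 3.2-fold lower number from compound 1 to compound 3 (0.50 log units; beyond the scatter) and so counts as a real change. The earlier step swapped one group for another, whereas this one shows that where the methyl sits on the phenyl ring matters by itself, even though 2-methylphenyl and 3-methylphenyl count the same under every tally of atoms and rings. On these data alone, whether a chlorine or an amine in place of the methyl of compound 3 would give a lower or higher number remains open. Nothing shown explains the direction of this shift.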